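The source may report more compounds than this note shows. Statements on the series, on what has been measured and on what is new or still open speak of the compounds shown alone.

Working notes on the series. Compound 1 `C[Se]/C(=N\C(=O)c1ccco1)NC(=O)c1ccco1` and compound 2 `CS/C(=N\C(=O)c1ccco1)NC(=O)c1ccco1` share one core; the core of compound 3 `CS/C(=N\C(=O)c1cc(-c2ccccc2)nc2ccccc12)NC(=O)c1cc(-c2ccccc2)nc2ccccc12` differs from that of compound 2, and the difference between the two cores is not broken down here. Compound 4 `C[Se]/C(=N\C(=O)c1cc(-c2ccccc2)nc2ccccc12)NC(=O)c1cc(-c2ccccc2)nc2ccccc12` remains unmeasured. In a functional assay on MCF7 cells (Homo sapiens) for cytotoxicity, read by MTT assay, with a stated time of 72 h (on this read-out higher numbers stand for lower toxicity in this test and lower numbers for higher toxicity in this test), compound 1 gives only a limit of the assay, > 100000 nM. In this assay compound 2 likewise gives a limit, > 100000 nM. In this assay compound 3 also gives a limit, > 100000 nM. The change from compound 2 to compound 1 is a group of 2 heavy atoms (1 carbon, 1 selenium; no ring) in place of a group of 2 heavy atoms (1 carbon, 1 sulfur; no ring), on a carbon with a double bond to nitrogen and its step that the two limits leave unreadable from compound 2 to compound 1 is unreadable because of the limit of > 100000 nM in this assay, at which 3 of the 3 values shown sit. The same change, at the same place, is made from compound 3 to compound 4 as a group of 2 heavy atoms (1 carbon, 1 selenium; no ring) in place of a group of 2 heavy atoms (1 carbon, 1 sulfur; no ring), on a carbon with a double bond to nitrogen. In this assay a step that the limit leaves unreadable from compound 3 to compound 4 is expected, resting on a step that the two limits leave unreadable from compound 2 to compound 1 staying unreadable. Compound 4 is estimated at 150000 nM, most likely again as a limit.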

Compound 4, concentration lethal to 50% of the cells: > 100000 nM
Compound 4: only a limit was reported; the forecaster's own chance of this, stated with the estimate: 85%; the middle value lies beyond the limit too.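

No new step can be read for compound 3 and compound 4 in this assay, because both values are limits of the assay: the limit of > 100000 nM in this assay, at which 4 of the 4 values shown sit.

The compounds shown leave open whether the selenium-bearing group in place of methylsulfanyl changes cytotoxicity on either core.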